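This account rests on a few compounds, and the source may have more. Where it says the series, first, only, none or still open, it means among the compounds named here.

Among the measured compounds shown here, compound 1 `Cc1cc(O)cc(-c2nn(CC#N)cc2-c2ccnc(-c3ccc(Oc4ccccc4)cc3)c2)c1` and compound 2 `COc1cc(C)cc(-c2nn(CC#N)cc2-c2ccnc(-c3ccc(N(C)C)cc3)c2)c1` share one core but differ at two places, so no single step links them. In a functional assay on SNB-19 cells (Homo sapiens) for cytotoxicity, read by sulforhodamine B assay, with a stated time of 48 h, tested at 0.01 uM (a higher number here means a weaker effect of the compound at the concentration tested, a lower number a stronger effect), compound 1 gives 100% and compound 2 gives 97%; these two numbers lie within the scatter of each other, and neither can be set apart. Compound 3 `Cc1cc(O)cc(-c2nn(CC#N)cc2-c2ccnc(-c3ccc(N(C)C)cc3)c2)c1` is the next member for this assay; the change from compound 2 is hydrogen in place of methyl on an oxygen on an aromatic ring. The step of a number 1 percentage points higher from compound 2 to compound 3 (within the scatter) is expected to be none beyond the scatter, given that compound 2 already sits at 97%. Compound 3 is estimated at 98%, with a range from 90% to 104%.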

Compound 3, a percentage reported as activity, at one concentration (the size of the read-out at that concentration, not a potency): 95%
Estimate against measurement, compound 3: 3 percentage points above; measured number inside the range.
By their numbers in this assay, from the lowest: compounds 3, 2 and 1 (each within the scatter of the next).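

In this assay, the change from methoxy to hydroxy on the aromatic ring gives a number 2 percentage points lower from compound 2 to compound 3 (within the scatter) and so does not separate the two groups at this position at the concentration tested. The other place now also has a single-step reading: dimethylamino in place of phenoxy on an aromatic carbon gives a number 5 percentage points lower from compound 1 to compound 3 (within the scatter) and likewise does not separate those two groups. No available evidence bears on these results. Going by these compounds, whether an amine or a carboxylic acid in place of the hydroxy would move the read-out remains open. So does the effect of a longer chain on that oxygen.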